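Removing both substituents from the benzamide ring

The compounds below may be only part of what the source reports. "The series", "measured", "known", "first", "only" and "open" are said of these compounds alone.

Compound 1, `CCOC(=O)N1CCC(N2CCC[C@@H](NC(=O)c3ccccc3Cl)C2)CC1`, in a functional assay on CHO cells for agonist activity at muscarinic acetylcholine receptor M5 (Rattus norvegicus) (a higher number here means that more compound is needed for the effect, a lower number that less compound is needed), gives > 10000 nM.
Compound 2, `CCOC(=O)N1CCC(N2CCC[C@@H](NC(=O)c3ccc(F)cc3C)C2)CC1`, in this assay gives > 10000 nM.

Compound 1 sits at a limit of this assay rather than at a measured number. For the measured compounds named here, compound 2 likewise sits at a limit of this assay, so no number is known for it, only that more compound than the limit would be needed. Because of the limit of > 10000 nM in this assay, at which 2 of the 2 values shown sit, the change from compound 1 to compound 2, a step that the two limits leave unreadable from compound 1 to compound 2, cannot be read as a step of any size.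

Compound 3, `CCOC(=O)N1CCC(N2CCC[C@@H](NC(=O)c3ccccc3)C2)CC1`, differs from compound 2 in one place: phenyl in place of 4-fluoro-2-methylphenyl on a carbonyl carbon. Going by the values given here, the only measured step that touches this part of the molecule is the one from compound 1 to compound 2, and it is unreadable, so nothing here sets an expected size or direction for the change from compound 2 to compound 3. With two limits and no readable step, the most that can be said is that compound 3 would be expected to sit near the same limit again.

Compound 3 is estimated at 15000 nM, in a range from 5000 nM to 50000 nM. This estimate means an expected change of a step that the limit leaves unreadable from compound 2 to compound 3 from compound 2 to compound 3.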

Compound 3, half-maximal effective concentration: > 10000 nM
Compound 3 was reported as a limit (the forecaster's own chance of this, stated with the estimate: 80%); the middle value is on the limit's open side.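

Compound 3 also sits at a limit, so its steps from compound 1 and from compound 2 cannot be read as steps of any size, because of this shared limit: the limit of > 10000 nM in this assay, at which 3 of the 3 values shown sit.

Still open, on these data alone, is how much of each compound the effect really needs, and so whether 2-chlorophenyl, 4-fluoro-2-methylphenyl or phenyl on the carbonyl makes any difference in this assay.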